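A few compounds are considered here, and "the series" means these few. Any claim that something is new, unique, unknown or untested is made for them only; others in the source may bear on it.

Measured so far: compound 1, `COc1ccccc1-c1ccc(CNC(=O)NC2CCN(Cc3ccc(C)cc3)CC2)cc1`, giving 6.19 in an in vitro functional assay on HEK293 cells for antagonist activity at melanin-concentrating hormone receptor 1 (Homo sapiens), read by GTPgammaS binding, with a stated time of 45 min; a higher number here means a more potent compound, by a factor of ten per unit of this negative logarithm, a lower number a less potent compound; compound 2, `Cc1ccc(CN2CCC(NC(=O)NCc3ccc(-c4cccc(C#N)c4)cc3)CC2)cc1`, giving 6.39 in this assay.

Compound 2 stands at the top of the two numbers shown, but only by a number 0.20 log units higher from compound 1 to compound 2 (within the scatter). Compound 3, `Cc1ccc(CN2CCC(NC(=O)NCc3ccc(-c4ccccc4)cc3)CC2)cc1`, differs from compound 2 by hydrogen in place of cyano on an aromatic carbon. Going by the values given here, the one measured step that bears on this change, a number 0.20 log units higher from compound 1 to compound 2 (within the scatter), shows that swapping the substituent on this outer ring left the number within the scatter. No step beyond the scatter is therefore expected in this assay for compound 3, the expected step being a number 0.19 log units lower from compound 2 to compound 3 (within the scatter). Compound 3 is estimated at 6.2, in a range from 5.7 to 6.7.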

Compound 3, negative logarithm of the antagonist equilibrium constant: 5.98
Beside the measured number, compound 3's estimate is 0.22 log units above it; measured number inside the range.
By their numbers in this assay, from the lowest: compounds 3, 1 and 2 (each within the scatter of the next, the first and the last beyond it).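

In this assay, taking the nitrile off the outer ring gives a number 0.41 log units lower from compound 2 to compound 3 (beyond the scatter) and so, unlike the earlier swap of one substituent for another, shows a modest response at this position once 3-cyanophenyl becomes phenyl. Hydrogen in place of methoxy gives a number 0.21 log units lower from compound 1 to compound 3 (within the scatter) and so does not separate the bare ring from the 2-methoxyphenyl compound. Nothing measured here accounts for the effect of the nitrile.

On these data alone, whether an amine or a carboxylic acid in the nitrile's place would match or pass compound 2 stays open. So does whether a longer chain carrying the nitrile would keep the modest step.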